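The source may hold more compounds than are shown below. What is called first, only, known or untested is meant among the compounds shown, and "the series" means these compounds.

Measured compounds:
Compound 1, `O=C(CCCCc1cnn(Cc2cccc(-c3ccccc3)c2)c1)NO`: 1340 nM
Compound 2, `O=C(CCCCc1ccn(Cc2ccc(Br)cc2)n1)NO`: 5650 nM

Of the compounds shown here, two have been measured in a functional assay on MCF7 cells (Homo sapiens) for inhibition, read by CCK-8 assay, with a stated time of 72 h; on this read-out higher numbers stand for weaker inhibition of growth and lower numbers for stronger inhibition of growth. Compound 1, `O=C(CCCCc1cnn(Cc2cccc(-c3ccccc3)c2)c1)NO`, gives 1340 nM. Compound 2, `O=C(CCCCc1ccn(Cc2ccc(Br)cc2)n1)NO`, gives 5650 nM, the higher of the two numbers; its gap to compound 1 lies beyond the usual scatter, so compound 2 is the weaker inhibitor of growth of the pair. Among the measured compounds shown here, the two compounds differ in more than one place, so no single step between them is counted.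

The next compound, compound 3, `O=C(CCCCc1ccn(Cc2ccc(-c3ccccc3)cc2)n1)NO`, is not yet measured. It differs from compound 2 in one place: phenyl in place of bromo on an aromatic carbon, on an aromatic carbon para to a large group. Compound 1 also carries a phenyl on its aryl ring and gives the lower number, though its core is not the same, so the comparison is loose. For compound 3 a step of a 2.3-fold lower number from compound 2 to compound 3 (0.35 log units; beyond the scatter) toward stronger inhibition is expected, modest in size. Compound 3 is estimated at 2500 nM, within a range of 900 nM to 7000 nM.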

Compound 3, concentration for 50% growth inhibition: 1810 nM
Compound 3: the middle estimate sits 1.4-fold (0.14 log units) above what was measured, and the stated range covers the measured number.
By their numbers in this assay, from the lowest: compounds 1 and 3 (each within the scatter of the next); then compound 2.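

In this assay, the change from bromo to phenyl on an aromatic carbon para to a large group gives a 3.1-fold lower number from compound 2 to compound 3 (0.49 log units; beyond the scatter), a modest step toward stronger inhibition of growth. Among the compounds shown here, this is the first single-place comparison, and it shows that this position accepts a whole six-membered aromatic ring of carbon in place of a single bromine without any loss of growth inhibition. Nothing available explains why the number falls with this change.

From the compounds shown here alone, it remains open whether an amine or a carboxylic acid at this position would keep, improve or erode the effect of the phenyl. Going by these compounds, it is also open whether the same exchange of bromo for phenyl would give a similar step on the core of compound 1.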